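Swapping a furan for a thiophene on a dihydropyrimidine core

A few compounds are considered here, and "the series" means these few. Any claim that something is new, unique, unknown or untested is made for them only; others in the source may bear on it.

Compound 1 `CC1=C(C(=O)OCc2ccccc2)C(c2ccoc2)NC(=O)N1` and compound 2 `CC1=C(C(=O)OCc2ccccc2)C(c2cccs2)NC(=O)N1` share one core and differ in a single group. In an assay on membranes from HeLa cells for displacement of a labelled ligand from adenosine receptor A3 (Homo sapiens), read by scintillation counting, with a stated time of 180 min, tested at 1 uM (a lower number here means less inhibition, a higher number more inhibition at the concentration tested (going by the name of the read-out)), compound 1 gives 1%, while compound 2 gives 8%. The change between them is thiophen-2-yl in place of furan-3-yl on a saturated ring carbon, and the step it made was a number 7 percentage points higher from compound 1 to compound 2 (within the scatter), so the two numbers cannot be told apart with confidence.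

Compound 3 `COC(=O)C1=C(C)NC(=S)NC1c1ccoc1` has a different core; how its core differs from that of compound 1 is not broken down here. In this assay compound 3 gives 3%, a number that sits within the usual scatter of both compound 1 and compound 2, so no ordering among the three can be claimed.

Compound 4 `COC(=O)C1=C(C)NC(=S)NC1c1cccs1` has not been measured. It arises from compound 3 by thiophen-2-yl in place of furan-3-yl on a saturated ring carbon. Around the place of the change, the ring atom next to it bears a methoxycarbonyl group in compound 3, where in compound 1 it bears a large group, so this is the same kind of change as the one from compound 1 to compound 2, not the same change.

Given that the earlier step was a number 7 percentage points higher from compound 1 to compound 2 (within the scatter), the expected step from compound 3 to compound 4 is estimated as a number 4 percentage points higher from compound 3 to compound 4 (within the scatter). Compound 4 is therefore expected to give about 7% in this assay, with the estimate ranging from 0% to 18%.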

Compound 4, a percentage reported as inhibition, at one concentration (the size of the read-out at that concentration, not a potency): 1%
Compound 4: middle estimate off by 6 percentage points, on the high side; measured number inside the range.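

Putting thiophen-2-yl in place of furan-3-yl on the core of compound 3 gave, in this assay, a number 2 percentage points lower from compound 3 to compound 4 (within the scatter), so this step cannot be told from no change at all. Set beside the earlier step, the result gives no sign that the swap behaves differently on the two cores: the same change on two cores in this assay, a number 7 percentage points higher (within the scatter) from compound 1 to compound 2 and a number 2 percentage points lower (within the scatter) from compound 3 to compound 4, 9 percentage points apart, within the scatter of two such steps

Among the compounds shown here, that agreement is weak support for carrying the change from one core to the other: it shows only that the swap left no readable mark on either core at the one concentration tested, and it does not show that the swap has the same real effect on both, as any small effect of either sign could be hidden in the scatter.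

The compounds shown carry only furan-3-yl or thiophen-2-yl on the saturated ring carbon, so they leave open whether a phenyl ring, or a ring bearing an amine or a carboxylic acid, would give a number that stands clear of the scatter. Also open, as far as these compounds go, is whether the two cores would then respond alike, and what a longer chain in place of the methyl group would do.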